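From compound 3 to compound 4: swapping one side group

The compounds below may be only part of what the source reports. "The series", "measured", "known", "first", "only" and "open" are said of these compounds alone.

Measured in a functional assay on MCF7 cells (Homo sapiens) for antiproliferative activity, read by MTT assay, with a stated time of 48 h (a higher number here means a weaker inhibitor, a lower number a stronger inhibitor), so far
Compound 1 `CC(C)=CCC[C@]1(C)/C=C/[C@@H](OC(=O)C=C(C)C)[C@](C)(O)/C=C/C(=O)/C(C(=O)O)=C\C1` gives 16100 nM
Compound 2 `CC(C)=CCC[C@]1(C)/C=C/[C@@H](OC(=O)C=C(C)C)[C@](C)(O)/C=C/C(=O)/C(CN(C)C)=C\C1` gives 690 nM
Compound 3 `CC[Si](CC)(CC)C/C1=C/C[C@](C)(CCC=C(C)C)/C=C/[C@@H](OC(=O)C=C(C)C)[C@](C)(O)/C=C/C1=O` gives 3150 nM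

Compound 3 holds the middle of these three numbers, with compound 2 lower and compound 1 higher, and both gaps lie beyond the usual scatter.

What changes in compound 4 `CSC(=S)OC/C1=C/C[C@](C)(CCC=C(C)C)/C=C/[C@@H](OC(=O)C=C(C)C)[C@](C)(O)/C=C/C1=O` is one group, with a group of 5 heavy atoms (2 carbon, 1 oxygen, 2 sulfur; no ring) in place of a group of 7 heavy atoms (6 carbon, 1 silicon; no ring), on a saturated chain carbon bound to a double-bonded ring carbon as the whole difference from compound 3. Among the measured compounds shown here, no measured compound carries the entering group, so the evidence is indirect. The closest step changes the same place, a 4.6-fold higher number from compound 2 to compound 3 (0.66 log units; beyond the scatter) and counts as modest. Two further steps start from the carboxy compound, where a 23-fold lower number from compound 1 to compound 2 (1.37 log units; beyond the scatter) is large and a 5.1-fold lower number from compound 1 to compound 3 (0.71 log units; beyond the scatter) is modest. These steps show that the number moves when this group changes, but they point in both directions and say nothing specific about the entering group. In this assay no step beyond the scatter is therefore expected, although a modest step either way remains possible. The expected change is a 1.1-fold lower number from compound 3 to compound 4 (0.02 log units; within the scatter) in this estimate. Compound 4 is estimated at 3000 nM with an expected range of 1000 nM to 9000 nM around that middle.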

Compound 4, half-maximal inhibitory concentration: 900 nM
For compound 4 the middle estimate is 3.3-fold (0.52 log units) above the measured one, outside the stated range (below it).
By their numbers in this assay, from the lowest: compounds 2 and 4 (each within the scatter of the next); then compound 3; then compound 1.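

In this assay the group of 5 heavy atoms (2 carbon, 1 oxygen, 2 sulfur) improves on the silicon-bearing group at this saturated chain carbon (a 3.5-fold lower number from compound 3 to compound 4 (0.54 log units; beyond the scatter)), so the number at this position still has room to fall once the silicon group is gone. The step from the dimethylamino compound (a 1.3-fold higher number from compound 2 to compound 4 (0.12 log units; within the scatter)) shows that two groups of quite different atoms can give equivalent numbers here, so among these compounds a nitrogen at this place is not needed to reach that level. The step from the carboxy compound (an 18-fold lower number from compound 1 to compound 4 (1.25 log units; beyond the scatter)) adds a third replacement for the carboxy group that gives a clearly lower number, and none of the compounds shown goes against that pattern.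

Nothing measured alongside these numbers explains why the sulfur-bearing group gives this result.

The compounds shown leave open how a plain alcohol or an acetate ester would compare on this saturated chain carbon, which would help show whether the sulfur atoms matter at all. A longer carbon chain or a larger amine at the same place also remains untested among these compounds, so the limits of what this position tolerates are still unknown.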